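The source may report more compounds than this note shows. Statements on the series, on what has been measured and on what is new or still open speak of the compounds shown alone.

Measured so far in a functional assay on C6 cells (Rattus norvegicus) for cytotoxicity, read by MTT assay, with a stated time of 24 h, tested at 25 ug/mL; a lower number here means a stronger effect, a higher number a weaker effect of the compound at the concentration tested:
Compound 1, `Cc1nnc(SCC(=O)N/N=c2/scc(-c3ccc(F)cc3)n2-c2ccccc2)s1`, gives 50.1%.
Compound 2, `O=C(CSc1ncccn1)N/N=c1/scc(-c2ccc(F)cc2)n1-c1ccccc1`, gives 63.9%.

Among the measured compounds shown here, on these two numbers compound 1 stands lowest; compound 2 is its only neighbour, and the gap between them, a number 13.8 percentage points higher from compound 1 to compound 2 (beyond the scatter), lies beyond the scatter. That single step carries the change pyrimidin-2-yl in place of 5-methyl-1,3,4-thiadiazol-2-yl on a sulfur, so it speaks to the group hung from the sulfur and to nothing else.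

Compound 3, `Cc1ccc(-c2cs/c(=N/NC(=O)CSc3nnc(C)s3)n2-c2ccccc2)cc1`, has not yet been measured. It keeps the sulfur-linked 5-methyl-1,3,4-thiadiazol-2-yl of compound 1 and differs from it in one place only: methyl in place of fluoro on an aromatic carbon. Cut one bond further out, the difference reads 4-fluorophenyl to 4-methylphenyl.

For the measured compounds named here, no measured step touches this ring, so the step from compound 1 to compound 2 gives no guidance here, and there is no basis for expecting a move in either direction. The step is therefore expected to stay within the scatter, a number 1.9 percentage points higher from compound 1 to compound 3 (within the scatter). For compound 3 the estimate is 52%, ranging from 34% to 70%.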

Compound 3, a percentage reported as activity, at one concentration (the size of the read-out at that concentration, not a potency): 50.1%
For compound 3 the middle estimate is 1.9 percentage points above the measured one, and the stated range covers the measured number.
By their numbers in this assay, from the lowest: compounds 1 and 3 (each within the scatter of the next); then compound 2.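

In this assay, among the compounds shown here, the change to methyl in place of fluoro, on an aromatic carbon para to a large group, is the first measured change away from the sulfur-linked group, and it gives no change at the digits printed from compound 1 to compound 3 (within the scatter) as its step. For the compounds shown here, the one earlier step, which exchanged the group on the sulfur, was of another kind (a number 13.8 percentage points higher from compound 1 to compound 2 (beyond the scatter)), so within these three compounds a read-out shift beyond the scatter has been seen only for the group on the sulfur, and not for this exchange of 4-fluorophenyl to 4-methylphenyl. No measurement of any property of these groups bears on this outcome, so no reason for it can be offered.

As far as these compounds go, what stays open is whether this position would tolerate something other than these two small groups, such as an amine, a carboxylic acid or a longer chain like n-butyl, with the read-out again within the scatter of compound 1. Also open, from the compounds shown here alone, is whether the exchange of fluoro and methyl would behave the same way with pyrimidin-2-yl on the sulfur.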